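Swapping a ring for an open chain on compound 3

The source may hold more compounds than are shown below. What is called first, only, known or untested is meant among the compounds shown, and "the series" means these compounds.

Values from a toxicity assay on HEK-293T cells (Homo sapiens) for cytotoxicity, read by MTT assay, with a stated time of 72 h (a higher number here means a weaker inhibitor, a lower number a stronger inhibitor), follow
Compound 1 `CN(C)CCCCCn1c2c(c3ccccc31)C(=O)c1c[n+]([O-])c3ccccc3c1C2=O` gives 70 nM
Compound 2 `O=C1c2c[n+]([O-])c3ccccc3c2C(=O)c2c1c1ccccc1n2Cc1cn([C@H]2O[C@H](CO)[C@@H](O)[C@H]2O)nn1` gives 1370 nM
Compound 3 `O=C1c2c[n+]([O-])c3ccccc3c2C(=O)c2c1c1ccccc1n2Cc1cn([C@@H]2C[C@H](O)[C@@H](CO)O2)nn1` gives 820 nM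

Compound 3 (820 nM) cannot be told apart from compound 2 (1370 nM), since the two lie within the scatter of each other. Both numbers are well above that of compound 1 (70 nM), so both compounds are clearly less toxic to these cells.

The next compound to consider is compound 4 `O=C1c2c[n+]([O-])c3ccccc3c2C(=O)c2c1c1ccccc1n2Cc1cn(C[C@H](O)CO)nn1`, which keeps the shared core. Here 2,3-dihydroxypropyl stands in place of 4-hydroxy-5-(hydroxymethyl)oxolan-2-yl on an aromatic nitrogen (2,3-dihydroxypropyl in place of 4-hydroxy-5-(hydroxymethyl)oxolan-2-yl on an aromatic nitrogen).

Within the data shown here, only one measured step touches this part of the molecule, and it stays within the scatter (a 1.7-fold lower number from compound 2 to compound 3 (0.22 log units; within the scatter)). That step swaps hydrogen for hydroxy on a saturated ring carbon but keeps the ring, so it is only an indirect guide. Among the measured compounds shown here, no measured step removes the ring. The expectation in this assay is therefore no step beyond the scatter, in either direction, though with real uncertainty. The estimated change is small (a 1.2-fold higher number from compound 3 to compound 4 (0.09 log units; within the scatter)). For compound 4 the expected value is 1000 nM (estimated range 400 nM to 2500 nM).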

Compound 4, half-maximal inhibitory concentration: 8880 nM
The estimate for compound 4 lay 8.9-fold (0.95 log units) below the measured number, and the stated range ends below it.
By their numbers in this assay, from the lowest: compound 1; then compounds 3 and 2 (each within the scatter of the next); then compound 4.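

In this assay, replacing the ring of 4-hydroxy-5-(hydroxymethyl)oxolan-2-yl with the open 2,3-dihydroxypropyl chain on the aromatic nitrogen gives a clear change at this position, with an 11-fold higher number from compound 3 to compound 4 (1.03 log units; beyond the scatter), and the comparison with the other ring-bearing compound points the same way, with a 6.5-fold higher number from compound 2 to compound 4 (0.81 log units; beyond the scatter). The earlier step kept the ring and stayed within the scatter, so only now does it appear that this position responds to more than the loss of one hydroxy; the number of hydrogen-bond donors is the same in both groups, so that count alone does not follow the change, and the distance from the 4-(dimethylamino)butyl compound grows to a 130-fold higher number from compound 1 to compound 4 (2.10 log units; beyond the scatter), leaving compound 4 with the highest number of the four. Nothing measured here explains this change.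

The compounds shown leave open whether the ring itself matters or the extra atoms it carries, a question that a cyclopentyl group bearing hydroxy groups could help to separate. They also leave open how a longer chain with hydroxy groups, or an open chain ending in a carboxylic acid, would behave at this position.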